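Notes on swapping methyl for fluoro on the phenyl group

The source may report more compounds than this note shows. Statements on the series, on what has been measured and on what is new or still open speak of the compounds shown alone.

- compound 1 `COc1ccccc1Oc1c(N)nc(-c2ccccc2)nc1OCCO`: > 80000 nM (a limit of the assay, not a number)
- compound 2 `COc1ccccc1Oc1c(N)nc(-c2cccc(C)c2)nc1OCCO`: 14700 nM
- compound 3 `COc1ccccc1Oc1c(N)nc(-c2ccc(C)cc2)nc1OCCO`: 6190 nM

All three results come from a functional assay on SK-MEL-28 cells (Homo sapiens) for cytotoxicity, read by CCK-8 assay, with a stated time of 24 h; on this read-out lower numbers stand for stronger inhibition and higher numbers for weaker inhibition. Compound 3 has the lower of the two actual numbers, and compound 2 is the nearest to it. Compound 4 `COc1ccccc1Oc1c(N)nc(-c2ccc(F)cc2)nc1OCCO` differs from compound 3 by fluoro in place of methyl on an aromatic carbon, para to a large group (fluoro in place of methyl on an aromatic carbon). Going by the values given here, no fluoro compound has been measured, so only the methyl steps bear on this change. The closest is an at least 12-fold lower number from compound 1 to compound 3 (1.11 log units; beyond the scatter), where methyl replaces hydrogen at the position in question. Moving the methyl gives a 2.4-fold lower number from compound 2 to compound 3 (0.38 log units; beyond the scatter), and methyl at the other position gives an at least 5.4-fold lower number from compound 1 to compound 2 (0.73 log units; beyond the scatter). Since the methyl of compound 3 accompanies the large step of an at least 12-fold lower number from compound 1 to compound 3 (1.11 log units; beyond the scatter), its replacement is expected to give back part of that gain, a modest to moderate move towards a higher number in this assay. The expected change is a 2.9-fold higher number from compound 3 to compound 4 (0.46 log units; beyond the scatter). For compound 4 the estimate is 18000 nM, with an expected range of 6000 nM to 60000 nM.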

Compound 4, half-maximal inhibitory concentration: 20100 nM
Beside the measured number, compound 4's estimate is 1.1-fold (0.05 log units) below it; measured number inside the range.
By their numbers in this assay, from the lowest: compound 3; then compounds 2 and 4 (each within the scatter of the next). At a limit, above all of these: compound 1.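

At this position, para to a large group, fluoro does not stand in for methyl in this assay: a 3.2-fold higher number from compound 3 to compound 4 (0.51 log units; beyond the scatter), while compound 4 sits level with the 3-methylphenyl compound, a 1.4-fold higher number from compound 2 to compound 4 (0.14 log units; within the scatter). Fluoro in place of hydrogen still gives a step beyond the scatter, an at least 3.9-fold lower number from compound 1 to compound 4 (0.59 log units; beyond the scatter), so a gain at this position does not depend on methyl alone. That step has only one bound, and compound 1 gives a limit, not a number: the limit of > 80000 nM in this assay, at which 1 of the 4 values shown sits.

Going by these compounds, whether an ethyl, methoxy or chloro group in place of the methyl of compound 3 would hold the lower number remains open. Also open, on these data alone, is whether an amine or a longer chain at this position would be tolerated in this assay.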